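From 2-aminophenyl to hydroxy on an amide-type nitrogen

A few compounds are considered here, and "the series" means these few. Any claim that something is new, unique, unknown or untested is made for them only; others in the source may bear on it.

- compound 1 `O=C(NO)c1ccc(CNC(=O)c2n[nH]cc2NC(=O)c2c(Cl)cccc2Cl)cc1` gives 14600 nM here
- compound 2 `Nc1ccccc1NC(=O)c1ccc(CNC(=O)c2n[nH]cc2NC(=O)c2c(Cl)cccc2Cl)cc1` gives 7760 nM here
- compound 3 `Nc1ccccc1NC(=O)c1ccc(CNC(=O)c2n[nH]cc2NC(=O)c2ccccc2F)cc1` gives 6850 nM here

In a functional assay on SMMC-7721 cells (Homo sapiens) for inhibition, read by CCK-8 assay, with a stated time of 72 h (on this read-out lower numbers stand for stronger inhibition and higher numbers for weaker inhibition), compound 3 at 6850 nM sits within the scatter of compound 2 and gives a lower number only than compound 1 at 14600 nM in this small set. Compound 4 `O=C(NO)c1ccc(CNC(=O)c2n[nH]cc2NC(=O)c2ccccc2F)cc1` carries hydroxy in place of 2-aminophenyl on an amide-type nitrogen. The closest evidence is the same exchange in the opposite direction, made with 2,6-dichlorophenyl on the carbonyl carbon (a 1.9-fold lower number from compound 1 to compound 2 (0.27 log units; within the scatter)), a step within the scatter. The change at that carbonyl carbon (a 1.1-fold lower number from compound 2 to compound 3 (0.05 log units; within the scatter)) is also within the scatter, so the earlier exchange is expected to carry over roughly unchanged. Reversing it, the expected step in this assay is modest and toward a higher number (a 1.8-fold higher number from compound 3 to compound 4 (0.26 log units; within the scatter)). The estimate for compound 4 is 12500 nM (range 6000 nM to 26000 nM).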

Compound 4, half-maximal inhibitory concentration: 16700 nM
Estimate against measurement, compound 4: 1.3-fold (0.13 log units) below; the range from low to high includes it.
By their numbers in this assay, from the lowest: compounds 3, 2, 1 and 4 (each within the scatter of the next, the first and the last beyond it).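

In this assay, hydroxy in place of 2-aminophenyl on the amide-type nitrogen now gives a step beyond the scatter, a 2.4-fold higher number from compound 3 to compound 4 (0.39 log units; beyond the scatter), whereas the same exchange between compound 1 and compound 2 stayed within it. The two readings of this exchange agree, so it does not depend measurably on which of the two groups sits on the carbonyl carbon: the same change on two cores in this assay, a 1.9-fold lower number (0.27 log units; within the scatter) from compound 1 to compound 2 and a 2.4-fold lower number (0.39 log units; beyond the scatter) from compound 4 to compound 3, 1.3-fold (0.11 log units) apart, within the scatter of two such steps. The exchange of 2,6-dichlorophenyl for 2-fluorophenyl on the carbonyl carbon, a 1.1-fold higher number from compound 1 to compound 4 (0.06 log units; within the scatter), stays as small with hydroxy on the nitrogen as with 2-aminophenyl: the same change on two cores in this assay, a 1.1-fold lower number (0.05 log units; within the scatter) from compound 2 to compound 3 and a 1.1-fold higher number (0.06 log units; within the scatter) from compound 1 to compound 4, 1.3-fold (0.11 log units) apart, within the scatter of two such steps.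

The compounds shown leave open how much of the 2-aminophenyl group matters, since a plain phenyl without the amine, or a methoxy in place of hydroxy, on this nitrogen would separate those contributions. They also leave open whether the carbonyl carbon tolerates a group such as cyclohexyl as readily as the two aromatic groups.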